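Side-chain changes at the hydroxyl-bearing carbon: working notes

The source may hold more compounds than are shown below. What is called first, only, known or untested is meant among the compounds shown, and "the series" means these compounds.

Measured so far:
compound 1 `CCCCC(C)(C)[C@H](O)/C=C/C1C2CCC(O2)C1C/C=C\CCCC(=O)O` — > 1000000 nM
compound 2 `O=C(O)CCC/C=C\CC1C2CCC(O2)C1/C=C/[C@@H](O)C1CCCCC1` — 900 nM

In a functional assay (plasma) for inhibition, with Homo sapiens as the target (a higher number here means a weaker inhibitor, a lower number a stronger inhibitor), compound 1 reaches only a limit of the assay, > 1000000 nM. Among the compounds with values here, compound 2 `O=C(O)CCC/C=C\CC1C2CCC(O2)C1/C=C/[C@@H](O)C1CCCCC1` is the sole member of the pair with a number, giving 900 nM in this assay. The value of compound 1 is a limit (the limit of > 1000000 nM in this assay, at which 1 of the 2 values shown sits). Compound 2 is therefore the only reference point for what follows.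

Within the data shown here, the one measured step, an at least 1100-fold lower number from compound 1 to compound 2 (3.04 log units; beyond the scatter), shows that the group on this carbon decides whether anything is seen at all.

Compound 3 `O=C(O)CCC/C=C\CC1C2CCC(O2)C1/C=C/[C@@H](O)CCc1ccccc1` differs from compound 2 by phenethyl in place of cyclohexyl on a saturated chain carbon bound to a double-bonded chain carbon and an oxygen on a saturated carbon. Among the measured compounds shown here, no measured step covers an aromatic group here, and the single step available runs between a branched open chain and a closed ring, so it only says the position is sensitive; it does not set the direction for a phenethyl group. A modest loss is expected, with wide uncertainty, and the step from compound 2 to compound 3 is estimated at a 2.2-fold higher number from compound 2 to compound 3 (0.35 log units; beyond the scatter). For compound 3 the expected value is 2000 nM, within 300 nM to 20000 nM.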

Compound 3, half-maximal inhibitory concentration: > 1000000 nM
Compound 3: only a limit was reported (the forecaster's own chance of this, stated with the estimate: 15%); middle value at least 500-fold (2.69 log units) away from the limit.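

In this assay, phenethyl in place of cyclohexyl gives an at least 1100-fold higher number from compound 2 to compound 3 (3.04 log units; beyond the scatter), so a six-membered ring within the group on this carbon is not enough for a number to appear. Compound 1 and compound 3 each reach only a limit of the assay, so two different groups, 1,1-dimethylpentyl and phenethyl, end at the same limit: the limit of > 1000000 nM in this assay, at which 2 of the 3 values shown sit.

Among the three groups, cyclohexyl alone gives a measured value, and the step between compound 1 and compound 3 cannot be read, both values being limits.

Phenethyl differs from cyclohexyl both in having an aromatic ring and in having a chain that carries the ring, and the compounds shown do not separate these two changes. A phenyl group on this carbon would test the aromatic ring without the chain, and a 2-cyclohexylethyl group would test the chain without the aromatic ring, so these two groups would show which change accounts for the loss.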